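A Methoxy Group Enters at a Different Place

The compounds below may be only part of what the source reports. "The series", "measured", "known", "first", "only" and "open" are said of these compounds alone.

Of the compounds shown here, three built on one shared core have been tested in a functional assay on the whole organism with Rattus norvegicus as the target, at a dose of 3 mg/kg by the oral route; a higher number here means a stronger effect of the compound at the dose given, a lower number a weaker effect. Compound 1 `COc1cc(C(=O)Nc2nn[nH]n2)nc(-c2ccccc2)c1` gives 97%, compound 2 `O=C(Nc1nn[nH]n1)c1cccc(-c2ccccc2)n1` gives 74%, and compound 3 `Cc1cc(C(=O)Nc2nn[nH]n2)nc(-c2ccccc2)c1` gives 50%, which stands lowest of the three. Compound 1 differs from compound 2 in one place only, (methoxy in place of hydrogen on an aromatic carbon), and that change brought a number 23 percentage points higher from compound 2 to compound 1 (beyond the scatter). The core of compound 3 differs from that of compound 2 by methyl in place of hydrogen on an aromatic carbon, a change that brought a number 24 percentage points lower from compound 2 to compound 3 (beyond the scatter), while the exchange of one group for the other gave a number 47 percentage points lower from compound 1 to compound 3 (beyond the scatter).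

Compound 4 `COc1ccc(-c2cc(C)cc(C(=O)Nc3nn[nH]n3)n2)cc1` has not yet been measured in this assay. It differs from compound 3 by methoxy in place of hydrogen on an aromatic carbon. Within the data shown here, this is the same kind of change as the one that leads from compound 2 to compound 1, but not the same change: in compound 4 the methoxy enters on a six-membered aromatic ring of carbon only, para to a large group, whereas in compound 1 it sits on a six-membered aromatic ring with 1 nitrogen, meta to a group of 8 heavy atoms, meta to a phenyl group, opposite the ring nitrogen. That difference in place makes the earlier rise, a number 23 percentage points higher from compound 2 to compound 1 (beyond the scatter), only a loose guide, and a smaller step, a number 15 percentage points higher from compound 3 to compound 4 (beyond the scatter), is expected in this assay. Compound 4 is therefore estimated at 65%, expected to lie between 42% and 85%.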

Compound 4, a percentage reported as inhibition, in the whole organism at one dose (the size of the read-out at that dose, not a potency): 43%
The estimate for compound 4 lay 22 percentage points above the measured number; low and high end bracket the measured number.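

In this assay, methoxy in place of hydrogen on an aromatic carbon gave a number 7 percentage points lower from compound 3 to compound 4 (within the scatter), so at this place, on the six-membered aromatic ring of carbon only and para to a large group, the change had no effect that can be told from the scatter. Set beside the earlier step, the gain seen with methoxy did not carry over as a general rule for this series: the same change on two cores in this assay, a number 23 percentage points higher (beyond the scatter) from compound 2 to compound 1 and a number 7 percentage points lower (within the scatter) from compound 3 to compound 4, 30 percentage points apart, beyond the scatter of two such steps. This does not show why the two results part, since the pair differs in two things at once: the methoxy stands on a different ring, and the core of compound 4 carries a methyl group that compound 1 lacks, so the effect of the place cannot be separated from that of the core.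

The compounds shown leave open how methoxy on the ring of carbon only behaves on a core without the methyl group, and how methoxy on the ring with nitrogen behaves when a further group is present elsewhere. From the compounds shown here alone, it also remains open whether a hydroxyl group, an amine or a longer chain at the place taken by methoxy in compound 4 would read differently from hydrogen in this assay.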